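The source may report more compounds than this note shows. Statements on the series, on what has been measured and on what is new or still open speak of the compounds shown alone.

Compounds measured in a functional assay on T98G cells (Homo sapiens) for inhibition, read by MTT assay, with a stated time of 72 h; on this read-out lower numbers stand for stronger inhibition and higher numbers for weaker inhibition:
Compound 1 `CC1(C)CC(NC(=S)Nc2ccc(C#N)cc2)c2cc(Cl)ccc2O1` gives 10000 nM.
Compound 2 `CCNC(=S)NC1CC(C)(C)Oc2ccc(Cl)cc21` sits at the limit of > 100000 nM in this assay, at which 1 of the 2 values shown sits, so compound 2 gives only a limit of the assay, > 100000 nM.

Going by the values given here, compound 1 therefore stands as the only actual number in this assay; the other value is a limit. Among the compounds with values here, the single measured step, an at least 10-fold higher number from compound 1 to compound 2 (1.00 log units; beyond the scatter), replaces the whole aryl group on the thiourea nitrogen with ethyl and says nothing about exchanging one substituent on that ring for another. Compound 3 `CC1(C)CC(NC(=S)Nc2ccc([N+](=O)[O-])cc2)c2cc(Cl)ccc2O1` differs from compound 1 as follows: nitro in place of cyano on an aromatic carbon. Within the data shown here, no measured step covers such an exchange, and nothing in the data points to a shift in either direction. Compound 3 is accordingly expected to show no step beyond the usual scatter, no change at the digits printed from compound 1 to compound 3 (within the scatter). The estimate for compound 3 in this assay is 10000 nM, within a range from 3000 nM to 35000 nM.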

Compound 3, half-maximal inhibitory concentration: 4000 nM
Estimate against measurement, compound 3: 2.5-fold (0.40 log units) above; the measured number falls inside the stated range.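

In this assay the exchange of nitro for cyano on the aromatic carbon para to a large group gives a 2.5-fold lower number from compound 1 to compound 3 (0.40 log units; beyond the scatter) and so stays modest, yet it lies beyond the scatter. This shows that the number responds to a change of one substituent at this position while the aryl ring stays in place, something the earlier step could not show, as it replaced the whole aryl group with ethyl. No measurement shown here bears on why nitro gives the lower number.

The compounds shown leave open how the same position responds to other groups, such as an amine, a carboxylic acid or a plain hydrogen. They also leave open whether nitro would give a similar number on another carbon of the ring.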